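This account rests on a few compounds, and the source may have more. Where it says the series, first, only, none or still open, it means among the compounds named here.

Among the measured compounds shown here, compounds 1, 2 and 3 share one core, with only a single group changed among them. Compound 1 `Cc1cccc(C(Nc2ccc(C)cc2Cl)C(=O)CCc2ccncc2)c1` is the starting point. In an assay on isolated protein for binding affinity to corticotropin-releasing factor receptor 1 (Homo sapiens) (a higher number here means a weaker inhibitor, a lower number a stronger inhibitor), compound 1 gives > 10000 nM, which is a limit of the assay rather than a number. Compound 2 `COc1cccc(C(Nc2ccc(C)cc2Cl)C(=O)CCc2ccncc2)c1` carries a methoxy in place of methyl on an aromatic carbon, and in this assay compound 2 also gives > 10000 nM, again a limit. The step that the two limits leave unreadable from compound 1 to compound 2 therefore cannot be read from the two limits. Compound 3 `Cc1ccc(NC(C(=O)CCc2ccccn2)c2ccccc2Br)c(Cl)c1` is the compound from which the new one is built; in this assay compound 3 gives > 10000 nM, a limit as well. For the measured compounds named here, because of the limit of > 10000 nM in this assay, at which 3 of the 3 values shown sit, no measured step shows a usable size or direction. Compound 4 `Cc1ccc(NC(C(=O)CCc2ccccc2)c2ccccc2Br)c(Cl)c1` differs from compound 3 by phenyl in place of pyridin-2-yl on a saturated chain carbon, two bonds along the chain from a carbonyl carbon. With every measured value sitting at the limit, the expected step that the limit leaves unreadable from compound 3 to compound 4 is none beyond the scatter. Compound 4 is thus expected to give about 15000 nM, within a range of 3000 nM to 60000 nM.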

Compound 4, inhibition constant: > 10000 nM
Compound 4: a limit, no number; the forecaster's own chance of this, stated with the estimate: 80%; the middle value lies beyond the limit too.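

The change from pyridin-2-yl to phenyl between compound 3 and compound 4 gives no readable step, because both compounds stop at a limit rather than a number: the limit of > 10000 nM in this assay, at which 4 of the 4 values shown sit.

In this assay the compounds shown leave open whether any change to the shared core gives a measurable value, and how large such a step would be.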